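The compounds below may be only part of what the source reports. "The series", "measured", "known", "first", "only" and "open" are said of these compounds alone.

Compound 1 `COc1cc2c(Oc3ccc(NC(=O)c4nc(-c5ccc(F)cc5)no4)cc3)ccnc2cc1OCCCN1CCC(C)CC1`: 1040 nM
Compound 2 `COc1cc2c(Oc3ccc(NC(=O)C4(c5nnc(-c6ccc(F)cc6)o5)CC4)cc3F)ccnc2cc1OCCCN1CCN(C)CC1`: 1670 nM

Both compounds were measured in a functional assay on PC-3 cells (Homo sapiens) for antiproliferative activity, read by MTT assay, with a stated time of 72 h; on this read-out lower numbers stand for stronger inhibition and higher numbers for weaker inhibition. Compound 2 gives the higher of the two numbers, with compound 1 the nearest; the two values lie within the scatter of each other, so no order can be read from them. Going by the values given here, no single-point step connects the pair, as the two structures differ in more than one place.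

Compound 3 `COc1cc2c(Oc3ccc(NC(=O)C4(c5nnc(-c6ccc(F)cc6)o5)CC4)cc3F)ccnc2cc1OCCCN1CCC(C)CC1` differs from compound 2 in one place: 4-methylpiperidin-1-yl in place of 4-methylpiperazin-1-yl on a saturated chain carbon, three bonds along the chain from an oxygen on an aromatic ring. Compound 1 carries the same 4-methylpiperidin-1-yl group, but it departs from compound 2 elsewhere as well, so it offers no clean comparison for this change. Among the compounds with values here, no measured step for this change exists in the set. The step of a 1.3-fold lower number from compound 2 to compound 3 (0.11 log units; within the scatter) is expected to stay within the scatter, in no particular direction. Compound 3 is estimated at 1300 nM, with a range of 500 nM to 3400 nM in this assay.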

Compound 3, half-maximal inhibitory concentration: 2180 nM
For compound 3 the middle estimate is 1.7-fold (0.22 log units) below the measured one, within the range that was stated.
By their numbers in this assay, from the lowest: compounds 1, 2 and 3 (each within the scatter of the next, the first and the last beyond it).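

On a saturated chain carbon, three bonds along the chain from an oxygen on an aromatic ring, 4-methylpiperidin-1-yl was exchanged for 4-methylpiperazin-1-yl in this assay, giving a 1.3-fold higher number from compound 2 to compound 3 (0.12 log units; within the scatter) on an otherwise unchanged structure. Going by these compounds alone, this is the first clean reading at this position: replacing one ring nitrogen with carbon, which leaves the heavy-atom count the same and removes one hydrogen-bond acceptor, gives two numbers that cannot be told apart. No measurement available bears on the reason for this result.

Going by these compounds, whether morpholin-4-yl, dimethylamino or a carboxylic acid at the end of this chain would give a number beyond the scatter remains open. So does the effect of a longer chain carrying 4-methylpiperidin-1-yl.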